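Swapping an oxetane for an azetidine on a CXCR3 antagonist

The source may hold more compounds than are shown below. What is called first, only, known or untested is meant among the compounds shown, and "the series" means these compounds.

Measured so far:
Compound 1 `Cc1nc(C)n(CC(=O)N2CCN(c3sc(C(F)(F)F)nc3-c3nc4ccc(OC5COC5)cc4[nH]3)C[C@H]2C)n1` — 68 nM
Compound 2 `C[C@@H]1CN(c2sc(C(F)(F)F)nc2-c2nc3ccccc3[nH]2)CCN1C(=O)Cn1cc(C2CCN(C)CC2)cn1` — 15 nM

In a functional assay on CHO-K1 cells for antagonist activity at C-X-C chemokine receptor type 3 (Homo sapiens), read by FLIPR, with a stated time of 10 min, in the presence of a further agent that is not named here (a higher number here means a weaker inhibitor, a lower number a stronger inhibitor), compound 1 gives 68 nM, the higher of the two numbers recorded; compound 2, built on a differently decorated core, gives 15 nM. Compound 3 `Cc1nc(C)n(CC(=O)N2CCN(c3sc(C(F)(F)F)nc3-c3nc4ccc(OC5CNC5)cc4[nH]3)C[C@H]2C)n1` differs from compound 1 in one place: azetidin-3-yl in place of oxetan-3-yl on an oxygen on an aromatic ring. Among the measured compounds shown here, no measured pair shows what such a change does here, so the expected step is taken as small, within the usual scatter or slightly toward a lower number. Compound 3 is therefore estimated at 45 nM, between 15 nM and 140 nM, a step of a 1.5-fold lower number from compound 1 to compound 3 (0.18 log units; within the scatter).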

Compound 3, half-maximal inhibitory concentration: 3.8 nM
Compound 3: the middle estimate sits 12-fold (1.07 log units) above what was measured; the measured number lies below the stated range.
By their numbers in this assay, from the lowest: compound 3; then compound 2; then compound 1.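

On an oxygen on an aromatic ring, azetidin-3-yl in place of oxetan-3-yl brings an 18-fold lower number from compound 1 to compound 3 (1.25 log units; beyond the scatter) with no change in ring size or heavy-atom count, so this position is highly sensitive to the identity of that one ring atom. The swap also adds a hydrogen-bond donor, and this single pair cannot separate that from the change of oxygen to nitrogen. No measurement here explains the gain. Still open, as far as these compounds go, is whether 1-methylazetidin-3-yl or an open-chain 2-aminoethyl group on the same oxygen would keep it.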